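The source may hold more compounds than are shown below. What is called first, only, known or untested is meant among the compounds shown, and "the series" means these compounds.

Measured so far in a functional assay on MDA-MB-231 cells (Homo sapiens) for antiproliferative activity, read by sulforhodamine B assay, with a stated time of 48 h (on this read-out higher numbers stand for weaker inhibition of growth and lower numbers for stronger inhibition of growth), are these compounds:
- compound 1 `O=C(NCCCNc1cc(-c2cn(-c3ccccc3)nc2-c2cccc(O)c2)ccn1)Nc1ccc(F)cc1` at 7780 nM
- compound 2 `O=C(NCCCNc1cc(-c2cn(-c3ccccc3)nc2-c2cccc(O)c2)ccn1)Nc1cccc(C(F)(F)F)c1` at 7760 nM

With only these two numbers available, compound 1 has no rank of its own, since a 1.0-fold lower number from compound 1 to compound 2 (0.00 log units; within the scatter) and so the pair stands level. Compound 3 `COc1cccc(-c2nn(-c3ccccc3)cc2-c2ccnc(NCCCNC(=O)Nc3ccc(F)cc3)c2)c1` has yet to be measured in this assay and departs from compound 1 in one place, with methyl in place of hydrogen on an oxygen on an aromatic ring as the change, which turns hydroxy to methoxy, or 3-hydroxyphenyl to 3-methoxyphenyl. Among the compounds with values here, the one measured step bears on this only loosely. Within the data shown here, it concerns a group on an amide-type nitrogen, not the oxygen, and no measured step changes the group on that oxygen. Among the measured compounds shown here, it shows only that one change elsewhere on the shared core left the number in place. No direction can be drawn from it, so no step beyond the scatter is expected, and compound 1 at 7780 nM serves as the anchor. The expected change is a 1.2-fold higher number from compound 1 to compound 3 (0.06 log units; within the scatter) and this is a weakly supported estimate. For compound 3 the estimated value is 9000 nM with an expected range from 3500 nM to 25000 nM in this estimate.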

Compound 3, concentration for total growth inhibition: 23000 nM
Estimate against measurement, compound 3: 2.6-fold (0.41 log units) below; the measured number falls inside the stated range.
By their numbers in this assay, from the lowest: compounds 2 and 1 (each within the scatter of the next); then compound 3.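

In this assay the change from hydroxy to methoxy, or 3-hydroxyphenyl to 3-methoxyphenyl, is the first change shown to move the number beyond the scatter (a 3.0-fold higher number from compound 1 to compound 3 (0.47 log units; beyond the scatter)), whereas the earlier step on the amide-type nitrogen left the number in place (a 1.0-fold lower number from compound 1 to compound 2 (0.00 log units; within the scatter)). The oxygen on an aromatic ring is therefore a place on the shared core where adding a single methyl, just one carbon, goes with a modestly weaker inhibition of growth, so this position is less indifferent to change than the amide-type nitrogen was in that one step. Nothing available here bears on the cause of this shift.

The compounds shown leave open whether a larger group on that oxygen, such as ethoxy or benzyloxy, would go further in the same direction, and whether an amine or a fluorine in place of the hydroxy would behave like the hydroxy or like the methoxy. They also leave open whether the same change, made on compound 2 with its 3-(trifluoromethyl)phenyl, would give a step of similar size.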